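Urea series: methyl for iodo on the aryl ring

The source may hold more compounds than are shown below. What is called first, only, known or untested is meant among the compounds shown, and "the series" means these compounds.

Going by the values given here, in a physicochemical assay, with a stated time of 6 min (on this read-out lower numbers stand for stronger inhibition and higher numbers for weaker inhibition), compound 1 `O=C(Nc1ccc(I)cc1)Nc1nc(-c2cc3ccccc3o2)cs1` gives 62000 nM, one of only two numbers so far, the other being compound 2 `O=C(Nc1ccc(I)cc1)Nc1nc(-c2cc3cc([N+](=O)[O-])ccc3o2)cs1` at 62400 nM; the step of a 1.0-fold higher number from compound 1 to compound 2 (0.00 log units; within the scatter) lies within the scatter. Compound 3 `Cc1ccc(NC(=O)Nc2nc(-c3cc4ccccc4o3)cs2)cc1` differs from compound 1 by methyl in place of iodo on an aromatic carbon, sitting on an aromatic carbon of a six-membered aromatic ring of carbon only, para to a large group. Among the compounds with values here, no measured step touches this position, and the single measured step elsewhere did not move the number, so no step beyond the scatter is expected. Compound 3 is estimated at 65000 nM, range 25000 nM to 170000 nM. The expected step is a 1.0-fold higher number from compound 1 to compound 3 (0.02 log units; within the scatter).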

Compound 3, half-maximal inhibitory concentration: 500 nM
Beside the measured number, compound 3's estimate is 130-fold (2.11 log units) above it, and the stated range ends above it.
By their numbers in this assay, from the lowest: compound 3; then compounds 1 and 2 (each within the scatter of the next).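

Going by these compounds alone, at this position the number responds strongly: methyl in place of iodo gives a 120-fold lower number from compound 1 to compound 3 (2.09 log units; beyond the scatter) in this assay, whereas the only earlier step, on the other side of the molecule, stayed within the scatter. The change swaps one heavy atom for one, with the counts of hydrogen-bond donors and acceptors and net charge unchanged, so those counts do not separate the two compounds. Nothing at hand accounts for the size of this step.

Open, going by these compounds, is where an amine or a carboxylic acid at this position would fall relative to methyl and iodo. Also open, on these data alone, is whether the nitro change, which left the number flat with iodo present, stays flat on compound 3.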